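A few compounds are considered here, and "the series" means these few. Any claim that something is new, unique, unknown or untested is made for them only; others in the source may bear on it.

Measured in a functional assay on the whole organism with Mus musculus as the target; on this read-out lower numbers stand for an effect already at smaller amounts and higher numbers for an effect only at larger amounts of compound:
- Compound 1 `NCCC(c1cccc(F)c1)c1cccc(F)c1`: 9.7 mg/kg
- Compound 2 `CC(N)CC(c1cccc(F)c1)c1cccc(F)c1`: 5.1 mg/kg

Only these two compounds have been measured in this assay, and they cannot be told apart on these numbers. The measured step is a 1.9-fold lower number from compound 1 to compound 2 (0.28 log units; within the scatter). Compound 2 therefore stands level with compound 1 within the scatter.

The next compound, compound 3 `C[C@H](N)CC(c1cccc(F)c1)c1cccc(F)c1`, keeps the atoms and bonds of compound 2 and changes only in how one centre is drawn: the two compounds have the same atoms and bonds; at least one stereo element is drawn with a configuration in one of them and without one in the other: 1 of 1 stereo elements differ; a stereocentre at a saturated chain carbon is drawn without a configuration in compound 2 and S in compound 3. The stereocentre at a saturated chain carbon, drawn without a configuration in compound 2, is S in compound 3.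

Within the data shown here, the one measured step bears on this only loosely. It places a methyl in place of hydrogen on that same carbon, and it says nothing about configuration. Among the measured compounds shown here, no measured pair compares configurations, so no shift beyond the scatter is expected in either direction, and the range is kept wide. The expected change is a 1.0-fold lower number from compound 2 to compound 3 (0.01 log units; within the scatter). For compound 3 the estimated value is 5 mg/kg, with an expected range from 2.2 mg/kg to 11 mg/kg.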

Compound 3, dose for half-maximal effect: 7.3 mg/kg
The estimate for compound 3 lay 1.5-fold (0.16 log units) below the measured number, and the stated range covers the measured number.
By their numbers in this assay, from the lowest: compounds 2, 3 and 1 (each within the scatter of the next).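

In this assay, setting the stereocentre at the saturated chain carbon as S gives a 1.4-fold higher number from compound 2 to compound 3 (0.16 log units; within the scatter), so on these numbers the S form cannot be told apart from the form drawn without a configuration. With the S configuration drawn, methyl in place of hydrogen on that carbon gives a 1.3-fold lower number from compound 1 to compound 3 (0.12 log units; within the scatter), so the methyl leaves the number within the scatter whether or not a configuration is drawn. The new result therefore adds a comparison at this centre, but not one between two defined configurations, and it can show no preference for either of them: the fact that one of compounds 2 and 3 is drawn with a defined configuration and the other without, at the place where they differ

On these data alone, what the R configuration at this carbon would give stays open, and with it the question of whether the two configurations differ beyond the scatter in this whole-organism read-out. Also open, as far as these compounds go, is whether an ethyl group or a longer chain in place of the methyl, or a methyl on the amine nitrogen, would move the number beyond the scatter.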